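Propyl to Allyl on the Ring Nitrogen

This account rests on a few compounds, and the source may have more. Where it says the series, first, only, none or still open, it means among the compounds named here.

Compound 1, `O=c1[nH]c2ccccc2nc1-c1cccc([N+](=O)[O-])c1`, in an assay on cells for activation of Cystic fibrosis transmembrane conductance regulator (Homo sapiens), read by fluorescence, with a stated time of 10 min (a higher number here means that more compound is needed for the effect, a lower number that less compound is needed), gives only a limit: > 10000 nM.
Compound 2, `CCCn1c(=O)c(-c2cccc([N+](=O)[O-])c2)nc2ccccc21`, in this assay gives 177 nM.

For the measured compounds named here, compound 2 holds the only number measured here; the other value is a limit, namely (the limit of > 10000 nM in this assay, at which 1 of the 2 values shown sits). Going by the values given here, the single measured step, an at least 56-fold lower number from compound 1 to compound 2 (1.75 log units; beyond the scatter), puts a propyl chain on the aromatic nitrogen where compound 1 has hydrogen.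

Compound 3, `C=CCn1c(=O)c(-c2cccc([N+](=O)[O-])c2)nc2ccccc21`, keeps that chain but alters its outer end: vinyl in place of ethyl on a saturated chain carbon bound to an aromatic nitrogen. The measured step concerns adding the chain, not reshaping its tip, so it bears only loosely on this change. With the chain still present, no step beyond the scatter is expected, and compound 3 is estimated to sit close to compound 2, a change of a 1.0-fold lower number from compound 2 to compound 3 (0.02 log units; within the scatter). The expected value for compound 3 is 170 nM, within a range of 60 nM to 500 nM.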

Compound 3, half-maximal effective concentration: 55 nM
Compound 3: the middle estimate sits 3.1-fold (0.49 log units) above what was measured; the whole stated range lies above it.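

The earlier step showed only that a chain on the aromatic nitrogen makes a large difference; this change shows that the outer end of that chain matters too. With the chain length unchanged, vinyl in place of ethyl gives a 3.2-fold lower number from compound 2 to compound 3 (0.51 log units; beyond the scatter) in this assay, so a double bond at the tip is enough to move the result beyond the scatter. Allyl in place of hydrogen gives an at least 180-fold lower number from compound 1 to compound 3 (2.25 log units; beyond the scatter), a size that is only a bound, as compound 1 gives a limit and not a number: the limit of > 10000 nM in this assay, at which 1 of the 3 values shown sits.

The data do not tell why the double bond makes this difference, as a single pair cannot separate possible explanations. On these data alone, how a longer chain such as butyl, or an amine at the end of the chain, would compare with allyl remains open.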